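Swapping a thiazole for a pyrazole on the amide nitrogen

The source may hold more compounds than are shown below. What is called first, only, known or untested is meant among the compounds shown, and "the series" means these compounds.

Measured so far:
compound 1, `CCN(C(=O)COc1ccc(C)cc1)C(C)c1cccs1`: "not active" (no number reported)
compound 2, `Cc1ccc(OCC(=O)N(Cc2cccs2)c2nccs2)cc1`: 2240 nM
compound 3, `CCN(Cc1cccs1)C(=O)COc1cccc(C)c1`: 97 nM

These three compounds were tested in an assay on HEK293 cells for agonist activity at transient receptor potential cation channel subfamily M member 8 (Homo sapiens), read by fluorescence and calcium flux, with a stated time of 15 min; on this read-out higher numbers stand for an effect only at larger amounts of compound and lower numbers for an effect already at smaller amounts. Compound 1 was reported as not active, with no number attached. Of the two compounds with a number, compound 2 stands at the high end with 2240 nM, whereas compound 3 gives 97 nM, a difference far wider than the usual scatter, so compound 3 acts at clearly smaller amounts than compound 2.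

The next compound, compound 4 `Cc1ccc(OCC(=O)N(Cc2cccs2)c2c(C)n[nH]c2C)cc1`, has not yet been measured in this assay. It is built from compound 2 by one change: 3,5-dimethyl-1H-pyrazol-4-yl in place of 1,3-thiazol-2-yl on an amide-type nitrogen. Among the measured compounds shown here, no pair of measured compounds differs in exactly this way, so there is no measured step to lean on. For the measured compounds named here, the only guide is that compound 2 already sits at the weaker end of what has been seen.

Without a precedent, compound 4 is expected to stay close to compound 2, with a 1.6-fold higher number from compound 2 to compound 4 (0.19 log units; within the scatter) expected to fall at or only modestly beyond the scatter, and a weakening being somewhat more likely than a gain. The estimate for compound 4 in this assay is therefore 3500 nM, with a range from 800 nM to 15000 nM.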

Compound 4, half-maximal effective concentration: 0.3 nM
Estimate against measurement, compound 4: 12000-fold (4.07 log units) above; measured number outside the range, below it.
By their numbers in this assay, from the lowest: compound 4; then compound 3; then compound 2.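

In this assay, the group on the amide-type nitrogen proves able to change the result enormously: 3,5-dimethyl-1H-pyrazol-4-yl in place of 1,3-thiazol-2-yl gives a 7500-fold lower number from compound 2 to compound 4 (3.87 log units; beyond the scatter), a large step far beyond the scatter. Among the compounds shown here, the earlier compounds could not show this, as no two of them differ in one place only, so this is the first measured sign of how much a single change can do here. Both groups are five-membered aromatic rings with 2 hetero atoms, while the entering group has 7 heavy atoms against 5 and 1 hydrogen-bond donor against 0, but no measurement shown ties the step to any of these differences.

The compounds shown leave open whether the two methyl groups are needed, since a plain pyrazol-4-yl group without them would be required to separate their share from that of the ring itself. As far as these compounds go, it also remains open whether other groups at this place, such as a phenyl or a pyridyl ring, would give numbers nearer to that of compound 4 or of compound 2.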